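Methyl on the benzamide ring of a thiadiazole catechol

The source may hold more compounds than are shown below. What is called first, only, known or untested is meant among the compounds shown, and "the series" means these compounds.

Compound 1 `O=C(Nc1nnc(-c2cccc(O)c2O)s1)c1ccccc1`: 21800 nM
Compound 2 `CC(=O)Nc1nnc(-c2ccc(O)c(O)c2)s1`: 125000 nM
Compound 3 `O=C(Nc1nnc(-c2ccc(O)c(O)c2)s1)C1CCCCC1`: 34500 nM

Of the compounds shown here, three on a shared core have been measured in a functional assay on HeLa cells (Homo sapiens) for cytotoxicity, read by MTT assay, with a stated time of 72 h; a higher number here means a weaker inhibitor, a lower number a stronger inhibitor. Compound 1 gives the lowest number of the three; compound 3 sits within the scatter of it, while compound 2 stands well apart with a higher number. Going by the values given here, the one comparable step, a 3.6-fold lower number from compound 2 to compound 3 (0.56 log units; beyond the scatter), shows that enlarging the group on the carbonyl carbon lowers the number modestly.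

Compound 4 `Cc1ccc(C(=O)Nc2nnc(-c3cccc(O)c3O)s2)cc1` differs from compound 1 by methyl in place of hydrogen on an aromatic carbon. This change sits on the aromatic ring of the amide rather than on the carbonyl carbon itself, and it adds far less than the step from compound 2 to compound 3 did. Among the compounds with values here, that step is the only guide, and it points weakly toward a lower number for a larger acyl group, but a single methyl is a small addition. Compound 4 is therefore expected to show a step of a 1.3-fold lower number from compound 1 to compound 4 (0.11 log units; within the scatter), which lies within the scatter. The estimate for compound 4 in this assay is 17000 nM, with a range from 7000 nM to 40000 nM.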

Compound 4, half-maximal inhibitory concentration: 13400 nM
Estimate against measurement, compound 4: 1.3-fold (0.10 log units) above; low and high end bracket the measured number.
By their numbers in this assay, from the lowest: compounds 4, 1 and 3 (each within the scatter of the next, the first and the last beyond it); then compound 2.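

Where the earlier step changed the group on the carbonyl carbon, compound 4 is the first to probe the aromatic ring of the amide, at the carbon para to a large group. In this assay, going from phenyl to 4-methylphenyl gives a 1.6-fold lower number from compound 1 to compound 4 (0.21 log units; within the scatter) and so stays within the scatter, showing that a single methyl at this position does not measurably shift the number. No available evidence bears on the reason for this result.

The compounds shown leave open whether a larger or different group at this carbon, such as a longer chain like butyl, an amine or a carboxylic acid, would move the number beyond the scatter. They also leave open whether methyl on another carbon of this ring would do so.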